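This account rests on a few compounds, and the source may have more. Where it says the series, first, only, none or still open, it means among the compounds named here.

Compound 1 `CN(C)c1ncnc2c1c(-c1ccoc1)cn2[C@@H]1O[C@H](CO)[C@@H](O)[C@H]1O` gives 14900 nM in a functional assay on K562 cells (Homo sapiens), read by MTT assay, with a stated time of 72 h; a higher number here means a weaker inhibitor, a lower number a stronger inhibitor. Compound 2 `CNc1ncnc2c1c(-c1cccs1)cn2[C@@H]1O[C@H](CO)[C@@H](O)[C@H]1O` gives only a limit of the assay, > 20000 nM in this assay.

Compound 2 thus stands at the upper limit of the measurements, (the limit of > 20000 nM in this assay, at which 1 of the 2 values shown sits), and carries no number of its own. Compound 3 `CN(C)c1ncnc2c1c(-c1cccs1)cn2[C@@H]1O[C@H](CO)[C@@H](O)[C@H]1O` differs from compound 2 in one place: methyl in place of hydrogen on a nitrogen on an aromatic ring. Among the measured compounds shown here, no step between measured compounds is available to size this change, so the expected shift from compound 2 to compound 3 in this assay is no larger than the scatter, an at least 1.1-fold lower number from compound 2 to compound 3 (0.04 log units; that floor lies within the scatter). Compound 3 is estimated at 18000 nM, within a range from 8000 nM to 40000 nM.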

Compound 3, half-maximal inhibitory concentration: > 20000 nM
Compound 3 was reported as a limit; the forecaster's own chance of this, stated with the estimate: 40%; at least 1.1-fold (0.04 log units) between middle value and limit.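

Methyl in place of hydrogen on the nitrogen leaves compound 3 at a limit of the assay, as compound 2 is, so the step between them cannot be read. Among the compounds shown here, with the dimethylamino group held in common, thiophen-2-yl in place of furan-3-yl on an aromatic carbon gives an at least 1.3-fold higher number from compound 1 to compound 3 (0.12 log units; that floor lies within the scatter) in this assay, the only readable step here, and it shows no change beyond the scatter.

As far as these compounds go, whether a plain amine in place of dimethylamino, or a phenyl ring in place of thiophen-2-yl, would move the number in this assay stays open.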